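Swapping a Difluoropiperidine for a Dimethyltriazole

The source may hold more compounds than are shown below. What is called first, only, known or untested is meant among the compounds shown, and "the series" means these compounds.

Within the data shown here, compound 3 `C[C@@H]1CN(c2sc(C(F)(F)F)nc2-c2nc3ccccc3[nH]2)CCN1C(=O)CN1CCC(F)(F)CC1` gives 2430 nM in a functional assay on Venous blood for antagonist activity at C-X-C chemokine receptor type 3 (Homo sapiens), read by flow cytometry, with a stated time of 30 min, in the presence of a further agent that is not named here (on this read-out higher numbers stand for weaker inhibition and lower numbers for stronger inhibition), the highest of the three numbers measured so far. Compound 1 `Cc1nn(CC(=O)N2CCN(c3sc(C(F)(F)F)nc3-c3nc4ccccc4[nH]3)C[C@H]2C)cc1CN(C)C` gives 330 nM in this assay, and compound 2 `Cc1nc(C)n(CC(=O)N2CCN(c3sc(C(F)(F)F)nc3-c3nc4ccc(C5CCOCC5)cc4[nH]3)C[C@H]2C)n1` gives 123 nM. Among the measured compounds shown here, only one measured step ends at compound 3: a 7.4-fold higher number from compound 1 to compound 3 (0.87 log units; beyond the scatter), in which an aromatic azole on the chain carbon bound to the carbonyl gave way to the saturated fluorinated ring.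

Compound 4 `Cc1nc(C)n(CC(=O)N2CCN(c3sc(C(F)(F)F)nc3-c3nc4ccccc4[nH]3)C[C@H]2C)n1` differs from compound 3 by 3,5-dimethyl-1H-1,2,4-triazol-1-yl in place of 4,4-difluoropiperidin-1-yl on a saturated chain carbon bound to a carbonyl carbon. This change restores an aromatic azole at the same place and so runs opposite in kind to the step from compound 1 to compound 3. For the measured compounds named here, compound 2 carries the same dimethyltriazole, but it also bears a tetrahydropyranyl group on the shared core, so no single step connects it to compound 4; its number merely shows that the dimethyltriazole is compatible with a low value.

A lower number is therefore expected for compound 4, of a size comparable to the step from compound 1 to compound 3 given above, and the estimate amounts to a 6.9-fold lower number from compound 3 to compound 4 (0.84 log units; beyond the scatter). Compound 4 is estimated at 350 nM in this assay, within a range of 120 nM to 1000 nM.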

Compound 4, half-maximal inhibitory concentration: 237 nM
Compound 4: the middle estimate sits 1.5-fold (0.17 log units) above what was measured; the range from low to high includes it.
By their numbers in this assay, from the lowest: compounds 2, 4 and 1 (each within the scatter of the next, the first and the last beyond it); then compound 3.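

The replacement of 4,4-difluoropiperidin-1-yl on a saturated chain carbon bound to a carbonyl carbon now has a direct measure with 3,5-dimethyl-1H-1,2,4-triazol-1-yl: a 10-fold lower number from compound 3 to compound 4 (1.01 log units; beyond the scatter), a large step, and the two azoles tested here both stand clear of compound 3. The two azoles themselves cannot be separated, with a 1.4-fold lower number from compound 1 to compound 4 (0.14 log units; within the scatter), and the oxan-4-yl group on an aromatic carbon does not register either, with a 1.9-fold higher number from compound 2 to compound 4 (0.28 log units; within the scatter). Nothing available explains the large step from the saturated ring to the dimethyltriazole.

The compounds shown leave open whether an unfluorinated piperidine or a morpholine at this place would fall with compound 3 or with the azoles. They also leave open whether a carboxylic acid on that aromatic carbon, in place of hydrogen or oxan-4-yl, would move the number beyond the scatter.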